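A few compounds are considered here, and "the series" means these few. Any claim that something is new, unique, unknown or untested is made for them only; others in the source may bear on it.

Of the compounds shown here, three have been measured in an assay on DDT1 cells (Cricetulus griseus) for binding affinity to adenosine receptor A1 (Homo sapiens), read by radioligand binding; on this read-out higher numbers stand for weaker inhibition and lower numbers for stronger inhibition. Compound 1 `C/N=C(\S)OC[C@H]1OC(n2cnc3c(NC4CCOC4)nc(Cl)nc32)[C@H](O)[C@@H]1O` gives 71 nM, compound 2 `CC(C)NC(=O)OC[C@H]1OC(n2cnc3c(NC4CCOC4)ncnc32)[C@H](O)[C@@H]1O` gives 78 nM, and compound 3 `O=C(NC1CCCC1)OC[C@H]1OC(n2cnc3c(NC4CCOC4)nc(Cl)nc32)[C@H](O)[C@@H]1O` gives 226 nM. Compound 2 therefore stands second highest of the three numbers; its number and that of compound 1 lie within the scatter of each other, while compound 3 stands clearly higher.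

The unmeasured compound 4 `O=C(NCc1ccccc1)OC[C@H]1OC(n2cnc3c(NC4CCOC4)ncnc32)[C@H](O)[C@@H]1O` differs from compound 2 in one place: benzyl in place of isopropyl on an amide-type nitrogen. Among the compounds with values here, the only measured step at this part of the molecule is a 3.2-fold higher number from compound 1 to compound 3 (0.50 log units; beyond the scatter), where a larger group took the place of a smaller one on the same oxygen and the number rose modestly. Within the data shown here, that step involves different groups, so it bears on the present change only loosely, but it is the sole guide, and it points to a modest weakening when more atoms are added here.

Compound 4 is therefore expected to show a 2.1-fold higher number from compound 2 to compound 4 (0.31 log units; beyond the scatter), with an estimated value of 160 nM and a range from 60 nM to 450 nM.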

Compound 4, inhibition constant: 1830 nM
The estimate for compound 4 lay 11-fold (1.06 log units) below the measured number; the whole stated range lies below it.
By their numbers in this assay, from the lowest: compounds 1 and 2 (each within the scatter of the next); then compound 3; then compound 4.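

In this assay, benzyl in place of isopropyl on the amide-type nitrogen gives a 23-fold higher number from compound 2 to compound 4 (1.37 log units; beyond the scatter) and the rest of the molecule stays the same. Within the data shown here, this is a large step, whereas the only earlier step at this part of the molecule was the modest 3.2-fold higher number from compound 1 to compound 3 (0.50 log units; beyond the scatter) and so gave no sign that one change here could cost so much. The position is thus far less forgiving of this change than the earlier compounds suggested, and nothing measured here explains the loss.

Still open, going by these compounds, is whether the loss follows from the aromatic ring itself or simply from the added carbons. A cyclohexylmethyl group on the same nitrogen would help separate the two, while a phenyl or a phenylethyl group would show how the length of the link to the ring matters.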